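Replacing the Aryl Group on a Saturated Ring Carbon

A few compounds are considered here, and "the series" means these few. Any claim that something is new, unique, unknown or untested is made for them only; others in the source may bear on it.

Going by the values given here, compound 2 `N#CC1=C(N)N(c2ccc(S(N)(=O)=O)cc2)C2=C(CCCC2)C1c1c(O)ccc2ccccc12` gives 20% in a functional assay on Ehrlich cells (Mus musculus) for cytotoxicity, read by trypan blue exclusion, with a stated time of 2 h, tested at 50 ug/mL (on this read-out higher numbers stand for a stronger effect at the one concentration tested and lower numbers for a weaker effect), the lower of the two numbers measured so far. Compound 1 `N#CC1=C(N)N(c2ccc(S(N)(=O)=O)cc2)C2=C(CCCC2)C1c1ccc(Cl)c(Cl)c1`, which carries a 3,4-dichlorophenyl group on the same saturated ring carbon, gives 50% in this assay. Among the compounds with values here, the only measured step, a number 30 percentage points lower from compound 1 to compound 2 (beyond the scatter), shows that the group on that carbon can move the read-out by a modest amount. Compound 3 `N#CC1=C(N)N(c2ccc(S(N)(=O)=O)cc2)C2=C(CCCC2)C1c1cccs1` carries a thiophen-2-yl group there instead: thiophen-2-yl in place of 2-hydroxynaphthalen-1-yl on a saturated ring carbon. Within the data shown here, no measured step involves a thiophen-2-yl group, so the single step at hand gives only loose guidance. Since compound 2 with its 2-hydroxynaphthalen-1-yl group gave the lower value 20%, a modest rise is expected on removing that group: a number 15 percentage points higher from compound 2 to compound 3 (beyond the scatter). For compound 3 the estimated value in this assay is 35%, within a range from 10% to 60%.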

Compound 3, a percentage reported as activity, at one concentration (the size of the read-out at that concentration, not a potency): 10%
The estimate for compound 3 lay 25 percentage points above the measured number; the range from low to high includes it.
By their numbers in this assay, from the lowest: compounds 3 and 2 (each within the scatter of the next); then compound 1.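

In this assay the exchange of 2-hydroxynaphthalen-1-yl for thiophen-2-yl gives a number 10 percentage points lower from compound 2 to compound 3 (within the scatter). At this saturated ring carbon, a group of 11 heavy atoms with a hydrogen-bond donor and a group of 5 heavy atoms with none therefore cannot be told apart on this read-out. The 3,4-dichlorophenyl group alone stands apart so far, with a number 40 percentage points lower from compound 1 to compound 3 (beyond the scatter), so the earlier drop from compound 1 now looks like a separation of compound 1 from the other two rather than a graded series.

Still open, as far as these compounds go, is whether the chlorine atoms or the phenyl ring of compound 1 go with its higher number, and what a plain phenyl, an aminophenyl or a carboxylic acid on a phenyl ring would give at this carbon. No measurement at hand offers a reason for any of these differences.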